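Working notes: two measured compounds, one estimate for compound 3

The compounds below may be only part of what the source reports. "The series", "measured", "known", "first", "only" and "open" are said of these compounds alone.

Compound 1, `C/C(=N\OCC(=O)O)c1ccccc1Cl`, gives < 20% in a functional assay on the whole organism for inhibition, with Rattus norvegicus as the target, read by paw edema, with stated times of 1 h and 3 h, at a dose of 50 mg/kg by the oral route; on this read-out higher numbers stand for more inhibition at the one dose given (going by the name of the read-out) and lower numbers for less inhibition; this value is a limit of the assay, not a number.
Compound 2, `C/C(=N\OCC(=O)O)c1ccc(CC2CCCCC2)cc1`, gives < 20% in this assay; this value is also a limit of the assay.

Compound 2 therefore stands at the limit of this assay, and nothing places it above or below compound 1, which sits at the same limit. Going by the values given here, no step between measured compounds can be drawn, because of the limit of < 20% in this assay, at which 2 of the 2 values shown sit. Among the compounds with values here, the series so far offers no measured change in paw edema inhibition on which to lean.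

Compound 3, `COc1ccc(/C(C)=N/OCC(=O)O)cc1`, is the next compound to be tested in this assay. The change from compound 2 is methoxy in place of cyclohexylmethyl on an aromatic carbon.

Within the data shown here, with both measured values resting at the limit, no step in this assay beyond the scatter is expected in either direction for this change, and the estimated step that the limit leaves unreadable from compound 2 to compound 3 reflects that. Compound 3 is expected to give about 15% in this assay, within a range of 0% to 35%, most likely again reported as a limit.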

Compound 3, a percentage reported as inhibition, in the whole organism at one dose (the size of the read-out at that dose, not a potency): < 20%
Compound 3: no number, only a limit; the forecaster's own chance of this, stated with the estimate: 60%; the middle value lies beyond the limit too.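

No step from compound 2 to compound 3 can be read in this assay, because these values are limits and not numbers: the limit of < 20% in this assay, at which 3 of the 3 values shown sit.

The compounds shown leave open whether methoxy in place of cyclohexylmethyl on an aromatic carbon changes the read-out at all, and whether any change to the shared core gives a measurable value in this assay.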